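Mouse liver microsome half-life: amide in place of cyclic group

This account rests on a few compounds, and the source may have more. Where it says the series, first, only, none or still open, it means among the compounds named here.

Measured so far:
compound 1 `CC(C)C(Cc1ncc[nH]1)c1ccc(-c2ccc3cccc(F)c3c2)[nH]c1=O`: < 0.0667 h
compound 2 `CC(C)C(c1ccc(-c2ccc3cccc(F)c3c2)[nH]c1=O)N1CCN/C1=N\C#N`: 0.207 h

In an ADME assay on microsomes from liver (Mus musculus) for metabolic stability (on this read-out lower numbers stand for a shorter-lived compound and higher numbers for a longer-lived compound), compound 1 gives < 0.0667 h, which is a limit of the assay and not a number. In this assay, going by the values given here, compound 2 gives 0.207 h, the only number so far. The entry of compound 1 is a limit, see (the limit of < 0.0667 h in this assay, at which 1 of the 2 values shown sits). Among the compounds with values here, the one measured step, an at least 3.1-fold higher number from compound 1 to compound 2 (0.49 log units; beyond the scatter), is the sole comparison available. Compound 3 `CC(C)NC(=O)CC(c1ccc(-c2ccc3cccc(F)c3c2)[nH]c1=O)C(C)C` is not yet measured. Its change from compound 2 is a group of 7 heavy atoms (5 carbon, 1 nitrogen, 1 oxygen; no ring) in place of a group of 8 heavy atoms (4 carbon, 4 nitrogen; one five-membered non-aromatic ring with 2 hetero atoms), on a saturated chain carbon bound to an aromatic carbon and a saturated chain carbon. The measured step does not bear on this exchange, since it concerned the five-membered aromatic ring leaving and the non-aromatic ring entering, not the non-aromatic ring leaving. Within the data shown here, with no step to lean on, a change of about a 1.4-fold lower number from compound 2 to compound 3 (0.14 log units; within the scatter) is expected for compound 3, not clearly beyond the scatter in either direction. Compound 3 is therefore estimated at 0.15 h, with a range of 0.05 h to 0.5 h.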

Compound 3, half-life: < 0.0667 h
Compound 3 gave a limit, no number; the forecaster's own chance of this, stated with the estimate: 20%; middle value at least 2.2-fold (0.35 log units) from the limit.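

In this assay, the number does not survive every exchange at this saturated chain carbon: replacing the non-aromatic ring with (isopropylcarbamoyl)methyl gives an at least 3.1-fold lower number from compound 2 to compound 3 (0.49 log units; beyond the scatter). Compound 2 is thus the only compound shown with a number, and neither the open chain amide of compound 3 nor the aromatic ring of compound 1 matches it. Compound 3 gives a limit and not a number, as compound 1 does, so the step between these two cannot be read: the limit of < 0.0667 h in this assay, at which 2 of the 3 values shown sit.

On these data alone, it remains open whether the nitrile or the non-aromatic ring of compound 2 accounts for the difference, and how a morpholine or a carboxylic acid would read at this place. Also open, as far as these compounds go, is whether compound 1 and compound 3 differ at all in this assay.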